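The source may hold more compounds than are shown below. What is called first, only, known or untested is meant among the compounds shown, and "the series" means these compounds.

Measured so far in a functional assay on U-373MG ATCC cells (Homo sapiens) for inhibition, read by colorimetric assay and MTT assay, with a stated time of 72 h; a higher number here means a weaker inhibitor, a lower number a stronger inhibitor:
- compound 1 `Cn1c2cnc1OCCCCCCCCCCOc1ccccc1-2`: 31000 nM
- compound 2 `C=CCCCCOc1cc2ccccc2cc1-c1cnc(OCCCCC=C)n1C`: 33000 nM
- compound 3 `CCCCCCOc1ncc(-c2ccccc2OC)n1C`: "not determined" (no result reported)

Compound 3 has no place on this scale, since its entry reads "not determined" (no result reported), so it offers no number to start from. Only compound 1 and compound 2 carry numbers, and these two values lie within the usual scatter of each other.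

Compound 4 `C=CCCCCOc1ncc(-c2ccccc2OC)n1C` comes from compound 3 through one small edit at the end of the chain: vinyl in place of ethyl on a saturated chain carbon, four bonds along the chain from an oxygen on an aromatic ring.

Among the compounds with values here, no measured pair shows this edit alone, so its size in this assay cannot be read from the data. The expectation is a step no larger than the scatter, in no particular direction. The nearest guide is compound 2, whose chains also end in vinyl and which gives 33000 nM. Compound 1, at 31000 nM, suggests the same weak range. A result reported only as a limit is also possible.

For compound 4 the expected value is 40000 nM, with an estimated range from 15000 nM to 100000 nM.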

Compound 4, half-maximal inhibitory concentration: 9000 nM
The estimate for compound 4 lay 4.4-fold (0.65 log units) above the measured number; measured number outside the range, below it.
By their numbers in this assay, from the lowest: compound 4; then compounds 1 and 2 (each within the scatter of the next).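

In this assay, within the data shown here, compound 4 gives 9000 nM, but compound 3 has no reported number, so no step between compound 3 and compound 4 can be read. The compounds shown leave open what vinyl in place of ethyl does on its own. Nothing shown accounts for the value of compound 4.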